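The source may hold more compounds than are shown below. What is called first, only, known or untested is meant among the compounds shown, and "the series" means these compounds.

Working notes on the series. In a functional assay on Vero cells (Chlorocebus sabaeus) for inhibition (a lower number here means a stronger inhibitor, a higher number a weaker inhibitor), compound 1 `COc1cc(/C=C/C(=O)c2cccc(NC(=O)c3ccco3)c2)ccc1O` gives 3.11 ug/mL and compound 2 `COc1cc(/C=C/C(=O)c2cccc(N)c2)ccc1O` gives 6.02 ug/mL, a pair within the scatter, a 1.9-fold higher number from compound 1 to compound 2 (0.29 log units; within the scatter). Compound 3 `COc1cc(/C=C/C(=O)c2cccc(NC(=O)c3ccc(Cl)c(Cl)c3)c2)ccc1O` gives > 50 ug/mL, which is a limit and not a number. Compound 4 `CCOC(=O)C(=O)Nc1cccc(C(=O)/C=C/c2ccc(O)c(OC)c2)c1` carries ethoxycarbonyl in place of 3,4-dichlorophenyl on a carbonyl carbon. For the measured compounds named here, two measured steps bear on this change: an at least 16-fold higher number from compound 1 to compound 3 (1.20 log units; beyond the scatter) and an at least 8.3-fold higher number from compound 2 to compound 3 (0.91 log units; beyond the scatter). As far as these compounds go, both lie beyond the scatter, and both end at the limit of compound 3, so their true sizes stay open. A large move to a lower number is therefore expected, with the expected step being an at least 7.1-fold lower number from compound 3 to compound 4 (0.85 log units; beyond the scatter). Compound 4 is expected at 7 ug/mL, with an estimated range of 2.5 ug/mL to 25 ug/mL.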

Compound 4, half-maximal inhibitory concentration: > 50 ug/mL
Compound 4: a limit, no number; the forecaster's own chance of this, stated with the estimate: 12%; middle value at least 7.1-fold (0.85 log units) from the limit.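

On the carbonyl carbon whose other neighbour is the amide-type nitrogen, the loss is no longer tied to 3,4-dichlorophenyl: ethoxycarbonyl, which has no ring, gives an at least 16-fold higher number from compound 1 to compound 4 (1.20 log units; beyond the scatter), and against the free amine it gives an at least 8.3-fold higher number from compound 2 to compound 4 (0.91 log units; beyond the scatter). Of the groups shown at this place, only furan-2-yl keeps a readable value in this assay. The step between compound 3 and compound 4 cannot be read, because both sit at a limit: the limit of > 50 ug/mL in this assay, at which 2 of the 4 values shown sit.

As far as these compounds go, the true values of compound 3 and compound 4 stay open. Also open, from the compounds shown here alone, is whether furan-2-yl is alone in keeping a readable value, or whether methyl or thiophen-2-yl on this carbonyl carbon would keep one too.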